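The compounds below may be only part of what the source reports. "The series", "measured", "known", "first", "only" and "open" are said of these compounds alone.

Compound 1 `O=C1N[C@H]2[C@H](CS[C@H]2CCCCCc2cn(Cc3ccccc3O)nn2)N1` was tested in an assay on isolated protein for inhibition of biotin--protein ligase (Homo sapiens), read by scintillation counting, with a stated time of 10 min; a higher number here means a weaker inhibitor, a lower number a stronger inhibitor. In this assay compound 1 reaches only the limit of > 16000 nM, not a measured number. Two near relatives, each differing in one place, are compound 2 `COc1cccc(Cn2cc(CCCCC[C@@H]3SC[C@@H]4NC(=O)N[C@@H]43)nn2)c1` and compound 3 `O=C1N[C@H]2[C@H](CS[C@H]2CCCCCc2cn(Cc3cccc(C(F)(F)F)c3)nn2)N1`. Compound 2 also stops at the limit, giving > 16000 nM. Compound 3 likewise gives only the limit > 16000 nM. Because all three sit at the limit of > 16000 nM in this assay, at which 3 of the 3 values shown sit, the steps a step that the two limits leave unreadable from compound 1 to compound 2, a step that the two limits leave unreadable from compound 1 to compound 3 and a step that the two limits leave unreadable from compound 2 to compound 3 cannot be read in size or direction. Compound 4 `O=C1N[C@H]2[C@H](CS[C@H]2CCCCCc2cn(Cc3ccc(I)cc3)nn2)N1` is not yet measured; it differs from compound 1 by 4-iodophenyl in place of 2-hydroxyphenyl on a saturated chain carbon bound to an aromatic nitrogen. The steps from compound 1 to compound 2 and to compound 3 touch the same place but give no readable size, so no direction can be expected. Compound 4 is estimated at 20000 nM, most likely again only a limit, within 8000 nM to 60000 nM, an expected step that the limit leaves unreadable from compound 1 to compound 4.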

Compound 4, inhibition constant: > 16000 nM
Compound 4: no number, only a limit; the forecaster's own chance of this, stated with the estimate: 85%; the middle value does not contradict the limit.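

Compound 4 also reaches only a limit, so its steps from compound 1, compound 2 and compound 3 cannot be read in size or direction: the limit of > 16000 nM in this assay, at which 4 of the 4 values shown sit.

The compounds shown leave open whether any replacement of the 2-hydroxybenzyl group of compound 1 gives a measured inhibition constant.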